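This account rests on a few compounds, and the source may have more. Where it says the series, first, only, none or still open, it means among the compounds named here.

Three compounds share one core and were tested the same way. Compound 1 `CC(C(=O)O)c1nn(Cc2cn3cc(OCC4CC4)c(Cl)cc3n2)c2ccccc2c1=O` gives 15 nM in a functional assay on HFL1 cells for antagonist activity at sphingosine 1-phosphate receptor 2 (Homo sapiens), read by ELISA, with a stated time of 24 h, in the presence of a further agent that is not named here; a higher number here means a weaker inhibitor, a lower number a stronger inhibitor. Compound 2 `C[C@@H](C(=O)O)c1nn(Cc2cn3cc(OCC4CC4)c(Cl)cc3n2)c2ccccc2c1=O` gives 3180 nM in this assay, and compound 3 `O=C(O)Cn1nc(Cn2cc3cc(OCC4CC4)c(Cl)cc3n2)c2ccccc2c1=O` gives 647 nM. Compound 2 therefore stands highest of the three numbers, the weakest inhibitor of the group, with compound 3 nearest to it and compound 1 furthest away. Among the compounds with values here, the only measured step that reaches compound 2 is a 210-fold higher number from compound 1 to compound 2 (2.33 log units; beyond the scatter), and it rests on a single point of difference: the fact that one of compounds 1 and 2 is drawn with a defined configuration and the other without, at the place where they differ.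

Compound 4 `COC(C(=O)O)c1nn(Cc2cn3cc(OCC4CC4)c(Cl)cc3n2)c2ccccc2c1=O` has not been measured. It differs from compound 2 by carboxy(methoxy)methyl in place of 1-carboxyethyl on an aromatic carbon. Like compound 1, compound 4 is drawn without a defined configuration at that chain carbon, so the large step from compound 1 to compound 2 bears on it; the methoxy in place of methyl has no measured counterpart here. A large step toward a lower number is expected, a 53-fold lower number from compound 2 to compound 4 (1.72 log units; beyond the scatter). Compound 4 is estimated at 60 nM, within 10 nM to 400 nM.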

Compound 4, half-maximal inhibitory concentration: 217 nM
The estimate for compound 4 lay 3.6-fold (0.56 log units) below the measured number; measured number inside the range.
By their numbers in this assay, from the lowest: compound 1; then compound 4; then compound 3; then compound 2.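

Methoxy in place of methyl on this saturated chain carbon gives a 14-fold higher number from compound 1 to compound 4 (1.16 log units; beyond the scatter) in this assay, with both compounds drawn without a configuration. Within the data shown here, the group on this carbon therefore matters in its own right, whereas the earlier compounds showed only a change in how the carbon's configuration is drawn. The other new step, a 15-fold lower number from compound 2 to compound 4 (1.17 log units; beyond the scatter), is harder to read, since it combines the change of group with the difference already met at this carbon: the fact that one of compounds 1 and 2 is drawn with a defined configuration and the other without, at the place where they differ

The compounds shown leave open how far the number of compound 4 depends on configuration, as no form of it with a defined configuration appears here. They also leave open how an ethyl or a hydroxy group on this carbon would compare with methyl and methoxy.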